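The source may hold more compounds than are shown below. What is called first, only, known or untested is meant among the compounds shown, and "the series" means these compounds.

Measured so far:
compound 1, `NCC(O)Cn1c(=O)n(C2OC(CO)[C@@H](O)[C@H]2O)c2nc(N)nc(O)c21`, 110%
compound 2, `C=CCn1/c(=N\C#N)n([C@H]2OC(CO)[C@@H](O)[C@H]2O)c2cc(N)nc(O)c21`, 85%
compound 3, `C=CCn1c(=O)n(Cc2ccccc2)c2nc(N)nc(O)c21`, 25%

In a functional assay on the whole organism (B cells) with Mus musculus as the target (a higher number here means a larger maximal response, a lower number a smaller maximal response), compound 1 gives the highest of the three numbers; compound 2 lies nearest to it, a number beyond the scatter below it, and compound 3 lies furthest off, also beyond the scatter. Compound 4, `NC(=O)Cn1c(=O)n(C2OC(CO)[C@@H](O)[C@H]2O)c2nc(N)nc(O)c21`, has not yet been measured in this assay. It differs from compound 1 in one place: carbamoyl in place of 2-amino-1-hydroxyethyl on a saturated chain carbon bound to an aromatic nitrogen. Going by the values given here, no step between measured compounds covers this change, so the expectation rests on compound 1 alone, whose 110% sets the starting point. Compound 4 is expected to give about 100% in this assay, a step of a number 10 percentage points lower from compound 1 to compound 4 (within the scatter) that is estimated to be small, downward if anything, and within the scatter, with a range from 70% to 120%.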

Compound 4, largest response reached (reported as maximal response), in percent of the reference or control that the assay uses: 32%
The estimate for compound 4 lay 68 percentage points above the measured number; measured number below the stated range.
By their numbers in this assay, from the lowest: compounds 3 and 4 (each within the scatter of the next); then compound 2; then compound 1.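

In this assay, the group on a saturated chain carbon bound to an aromatic nitrogen turns out to matter strongly: carbamoyl in place of 2-amino-1-hydroxyethyl brings a number 78 percentage points lower from compound 1 to compound 4 (beyond the scatter). Going by these compounds alone, this is the first change at this position that can be read alone, since the earlier compounds differed in more than one place. Nothing available explains the loss.

The compounds shown leave open whether the amine, the hydroxyl or the chain length of the 3-amino-2-hydroxypropyl group sustains the response. On these data alone, how a carboxylic acid or a longer aminoalkyl chain would read here also stays open.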